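Bromo for (dimethylamino)methyl on the pendant aryl ring

The source may report more compounds than this note shows. Statements on the series, on what has been measured and on what is new or still open speak of the compounds shown alone.

Compound 2 `CCc1nnc(-c2ccc(-c3ccccc3)cc2)n1-c1cccc(CN(C)C)c1C` stands at the weak end of the two numbers in hand: in an assay on C6 glioma cells for displacement of a labelled ligand from sodium- and chloride-dependent glycine transporter 1 (Rattus norvegicus), read by scintillation counting, with stated times of 30 min and 10 min (a higher number here means a weaker inhibitor, a lower number a stronger inhibitor), compound 2 gives 29000 nM, the highest of the pair. Among the measured compounds shown here, its neighbour compound 1 `CCc1nnc(-c2ccc(-c3ccccc3)cc2)n1-c1ccccc1C` gives 300 nM in this assay, and the single measured step, a 97-fold higher number from compound 1 to compound 2 (1.99 log units; beyond the scatter), shows how much was lost when the (dimethylamino)methyl was introduced. Compound 3 `CCc1nnc(-c2ccc(-c3ccccc3)cc2)n1-c1cccc(Br)c1C` now takes the opposite route: bromo in place of (dimethylamino)methyl on an aromatic carbon. For the measured compounds named here, the only step that bears on this change is a 97-fold higher number from compound 1 to compound 2 (1.99 log units; beyond the scatter), which removed the same group in the other direction and was large. Because compound 1 gives 300 nM without any group at that carbon, most of that loss is expected to be recovered in this assay; what the bromo itself adds is not known from these two compounds. The expected step is a 48-fold lower number from compound 2 to compound 3 (1.68 log units; beyond the scatter). Compound 3 is therefore expected near 600 nM, within 150 nM to 3000 nM.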

Compound 3, half-maximal inhibitory concentration: 2200 nM
Compound 3: middle estimate off by 3.7-fold (0.56 log units), on the low side, within the range that was stated.
By their numbers in this assay, from the lowest: compound 1; then compound 3; then compound 2.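

In this assay, bromo in place of (dimethylamino)methyl gives a 13-fold lower number from compound 2 to compound 3 (1.12 log units; beyond the scatter), so most of the loss seen at this aromatic carbon is tied to the (dimethylamino)methyl group and not to substitution there as such. Substitution is still not free: bromo in place of hydrogen gives a 7.3-fold higher number from compound 1 to compound 3 (0.87 log units; beyond the scatter), so compound 3 does not return to the level of compound 1. Across these three compounds the numbers run from hydrogen through bromo to (dimethylamino)methyl, and neither group at this carbon improves on hydrogen.

Going by these compounds, whether a fluoro or a methoxy at this carbon would stay closer to compound 1, or an amide would behave more like bromo than like the amine, remains open. Nothing at hand gives a reason for the gap between bromo and (dimethylamino)methyl.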